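This account rests on a few compounds, and the source may have more. Where it says the series, first, only, none or still open, it means among the compounds named here.

In a physicochemical assay for solubility, in phosphate buffer, at pH 7.4 (a higher number here means a more soluble compound, a lower number a less soluble compound), compound 1 `C[C@@H]1CN(C(=O)OC(C)(C)C)CCN1c1ncc(OCC2CCN(S(C)(=O)=O)CC2)cn1` gives < 5000 nM, a limit of the assay rather than a number.
In this assay compound 2 `C[C@@H]1CN(C(=O)OC(C)(C)C)CCN1c1ncc(OCc2ccc(-n3cnnn3)cc2)cn1` gives < 5000 nM, again only a limit.

Compound 2 therefore stands at the limit of < 5000 nM in this assay, at which 2 of the 2 values shown sit. Within the data shown here, the one measured step, a step that the two limits leave unreadable from compound 1 to compound 2, is of unknown size. Compound 3 `C[C@@H]1CN(C(=O)OC(C)(C)C)CCN1c1ncc(OCc2ccc(S(C)(=O)=O)cc2F)cn1` differs from compound 2 by 2-fluoro-4-(methylsulfonyl)phenyl in place of 4-(1H-tetrazol-1-yl)phenyl on a saturated chain carbon bound to an oxygen on an aromatic ring. Among the measured compounds shown here, with both measured values at the limit and the only related step unreadable, no direction can be read for this change. Compound 3 is expected to give 3000 nM, with a range of 500 nM to 15000 nM, meaning an expected step that the limit leaves unreadable from compound 2 to compound 3.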

Compound 3, solubility: < 5000 nM
Compound 3: no number, only a limit (the forecaster's own chance of this, stated with the estimate: 65%); the middle value lies beyond the limit too.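

In this assay, among these compounds, compound 3 gives < 5000 nM as a limit only, so no step among compound 1, compound 2 and compound 3 can be read: the limit of < 5000 nM in this assay, at which 3 of the 3 values shown sit.
On these data alone, whether these three compounds differ in solubility at all stays open.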